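Replacing a fluoropyridine with a difluorophenyl on the amide

The source may report more compounds than this note shows. Statements on the series, on what has been measured and on what is new or still open speak of the compounds shown alone.

Within the data shown here, compound 3 `O=C(COc1ccc2cc(/C=C3/SC(=O)NC3=O)ccc2c1)Nc1cccc(F)n1` gives, in an assay on isolated protein for inhibition of histone deacetylase 4 (Homo sapiens), with a stated time of 1 h (a lower number here means a stronger inhibitor, a higher number a weaker inhibitor), a value of 840 nM, the lowest of the three numbers measured so far. Compound 1 `O=C(COc1ccc2cc(/C=C3/SC(=O)NC3=O)ccc2c1)Nc1ccc(Br)cc1F` gives 1900 nM in this assay, and compound 2 `COc1cccc(NC(=O)COc2ccc3cc(/C=C4/SC(=O)NC4=O)ccc3c2)c1` gives 1600 nM. The steps run a 2.3-fold lower number from compound 1 to compound 3 (0.35 log units; beyond the scatter) and a 1.9-fold lower number from compound 2 to compound 3 (0.28 log units; within the scatter), while the step of a 1.2-fold lower number from compound 1 to compound 2 (0.07 log units; within the scatter) separates the two phenyl-bearing compounds only slightly. Compound 4 `O=C(COc1ccc2cc(/C=C3/SC(=O)NC3=O)ccc2c1)Nc1ccc(F)cc1F` differs from compound 3 in one place: 2,4-difluorophenyl in place of 6-fluoropyridin-2-yl on an amide-type nitrogen. Both earlier phenyl amides, compound 1 and compound 2, sit above compound 3, and the pyridine-to-phenyl step from compound 3 to compound 1 was the only one beyond the scatter, so a modest rise in the number, or none beyond the scatter, is expected here. His estimate for compound 4 in this assay is therefore 1500 nM, within the range 700 nM to 3200 nM, corresponding to an expected step of a 1.8-fold higher number from compound 3 to compound 4 (0.25 log units; within the scatter).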

Compound 4, half-maximal inhibitory concentration: 3900 nM
Beside the measured number, compound 4's estimate is 2.6-fold (0.41 log units) below it, and the stated range ends below it.
By their numbers in this assay, from the lowest: compounds 3, 2 and 1 (each within the scatter of the next, the first and the last beyond it); then compound 4.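

In this assay, among these compounds, the change from the 6-fluoropyridin-2-yl to the 2,4-difluorophenyl group gives a 4.6-fold higher number from compound 3 to compound 4 (0.67 log units; beyond the scatter) and so shows that this amide-type nitrogen tolerates a larger step than the earlier compounds revealed. The phenyl amides also separate here: a 2.4-fold higher number from compound 2 to compound 4 (0.39 log units; beyond the scatter) and, with fluoro in place of bromo on an aromatic carbon, a 2.1-fold higher number from compound 1 to compound 4 (0.31 log units; beyond the scatter) both lie beyond the scatter, whereas a 1.2-fold lower number from compound 1 to compound 2 (0.07 log units; within the scatter) did not. Nothing at hand accounts for these steps.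

Compound 4 differs from compound 3 in both the ring nitrogen and the fluoro pattern, so the compounds shown cannot separate the two. They also leave open how an unsubstituted pyridin-2-yl group, or a carboxylic acid or an amine on this ring, would read.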